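A few compounds are considered here, and "the series" means these few. Any claim that something is new, unique, unknown or untested is made for them only; others in the source may bear on it.

Compound 1 `CCCCOC(=O)CC1c2cccc(C)c2S(=O)(=O)N1C(C)=O` has no result in an assay on HEK-Blue hNOD1 cells for antagonist activity at Nucleotide-binding oligomerization domain-containing protein 1 (Homo sapiens), read by reporter gene assay, with stated times of 3 h and 20 h; a higher number here means a weaker inhibitor, a lower number a stronger inhibitor: for compound 1 the entry reads "not determined" (no result reported). Among the measured compounds shown here, compound 2 `CCCCOC(=O)CC1c2cccc(C)c2S(=O)(=O)N1C(=O)c1ccc(C(F)(F)F)cc1` is the only member of the series with a number: in this assay compound 2 gives 1310 nM, so it stands alone, with no second value to rank it against. Compound 3 `CCCCOC(=O)CC1c2ccc(Cl)c(C)c2S(=O)(=O)N1C(=O)c1ccc(C(F)(F)F)cc1` differs from compound 2 by chloro in place of hydrogen on an aromatic carbon. For the measured compounds named here, no measured pair shows a change of this kind, so no direction can be read from the numbers; the expected step from compound 2 to compound 3 is a 1.3-fold lower number from compound 2 to compound 3 (0.12 log units; within the scatter), not beyond the usual scatter. Compound 3 is therefore expected to give 1000 nM in this assay, in a range from 350 nM to 3000 nM.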

Compound 3, half-maximal inhibitory concentration: 8370 nM
Compound 3: middle estimate off by 8.4-fold (0.92 log units), on the low side, and the stated range ends below it.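

Chloro in place of hydrogen on this aromatic carbon, ortho to a methyl group, gives the first readable step in the series: in this assay, a 6.4-fold higher number from compound 2 to compound 3 (0.81 log units; beyond the scatter). This position therefore responds to substitution, and here the added chlorine weakens inhibition, although a single step establishes no trend. Nothing available explains the rise.

Going by these compounds, whether fluoro, methoxy or an amine on the same carbon would also raise the number remains open. So does whether the chloro step would hold with a different acyl group on the ring nitrogen.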